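Permeability of Acylsulfonamide Analogues: Predicting an Aminoethyl Variant

The compounds below may be only part of what the source reports. "The series", "measured", "known", "first", "only" and "open" are said of these compounds alone.

Measured compounds:
Compound 1 `O=C(NS(=O)(=O)c1ccc(F)cc1)c1ccc(Nc2nc(NC3(c4ccc(Cl)cc4)CC3)nc(OCC(F)(F)F)n2)cc1` gives 193 nm/s.
Compound 2 `CC(C)C(=O)NCCS(=O)(=O)NC(=O)c1ccc(Nc2nc(NC3(c4ccc(Cl)cc4)CC3)nc(OCC(F)(F)F)n2)cc1` gives 13 nm/s.
Compound 3 `CS(=O)(=O)NC(=O)c1ccc(Nc2nc(NC3(c4ccc(Cl)cc4)CC3)nc(OCC(F)(F)F)n2)cc1` gives 11 nm/s.

These three compounds share one core and differ only in the group attached to the sulfonyl sulfur. The read-out is a physicochemical assay for permeability, using PAMPA, at pH 7.4; on this read-out lower numbers stand for lower permeability and higher numbers for higher permeability. On these numbers compound 1 stands highest; its nearest neighbour is compound 2, and compound 3 lies furthest from it.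

The compound under consideration is compound 4 `NCCS(=O)(=O)NC(=O)c1ccc(Nc2nc(NC3(c4ccc(Cl)cc4)CC3)nc(OCC(F)(F)F)n2)cc1`. Relative to compound 1 the change is 2-aminoethyl in place of 4-fluorophenyl on a sulfonyl sulfur.

Among the measured compounds shown here, two measured steps bear directly on this. Both swap the 4-fluorophenyl on the sulfonyl sulfur for a small non-aromatic group: a 15-fold lower number from compound 1 to compound 2 (1.17 log units; beyond the scatter) and an 18-fold lower number from compound 1 to compound 3 (1.24 log units; beyond the scatter). Both steps are large and point the same way. Between the two small-group analogues themselves the difference is slight: a 1.2-fold lower number from compound 2 to compound 3 (0.07 log units; within the scatter). The 2-aminoethyl group of compound 4 is likewise small and non-aromatic, so the expected step in this assay is a large drop, in the same direction as those two steps: a 32-fold lower number from compound 1 to compound 4 (1.51 log units; beyond the scatter).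

Compound 4 is therefore estimated to give 6 nm/s in this assay, with a plausible range from 1 nm/s to 20 nm/s.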

Compound 4, apparent permeability: 153 nm/s
The estimate for compound 4 lay 26-fold (1.41 log units) below the measured number; measured number above the stated range.
By their numbers in this assay, from the lowest: compounds 3 and 2 (each within the scatter of the next); then compounds 4 and 1 (each within the scatter of the next).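

In this assay this position on the sulfonyl sulfur does not always give a low number when a small non-aromatic group replaces 4-fluorophenyl: 2-aminoethyl in that place leaves the two compounds within the scatter of each other (a 1.3-fold lower number from compound 1 to compound 4 (0.10 log units; within the scatter)). The change that matters here lies at the far end of the chain, since aminomethyl in place of hydrogen on the saturated chain carbon bound to the sulfonyl sulfur gives a large step up (a 14-fold higher number from compound 3 to compound 4 (1.14 log units; beyond the scatter)), and hydrogen in place of isopropylcarbonyl on the amine nitrogen gives another (a 12-fold higher number from compound 2 to compound 4 (1.07 log units; beyond the scatter)). Losing the 4-fluorophenyl therefore does not set the number by itself, as compound 2 and compound 3 sit low while compound 4 does not.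

Going by these compounds, it remains open whether a longer chain ending in an amine, a dimethylamino group on the same chain, or a carboxylic acid at the chain end would behave like the 2-aminoethyl group. Nothing available here explains why the free amine chain and its capped or shortened relatives differ so widely.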